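Adding a Formyl Group to a Weakly Cytotoxic Scaffold

A few compounds are considered here, and "the series" means these few. Any claim that something is new, unique, unknown or untested is made for them only; others in the source may bear on it.

Compound 1 `Fc1ccc(-c2cn3nc(Cc4ccc(Cl)cc4)sc3n2)cc1` is the reference. In a functional assay on HeLa cells (Homo sapiens) for cytotoxicity, with a stated time of 72 h (on this read-out lower numbers stand for stronger inhibition and higher numbers for weaker inhibition), compound 1 reaches only the limit of > 250000 nM, not a measured number. Compound 4 `O=Cc1c(-c2ccc(F)cc2)nc2sc(Cc3ccc(Cl)cc3)nn12` differs from compound 1 by formyl in place of hydrogen on an aromatic carbon. The measured steps all alter the aryl ring instead: compound 2 `Clc1ccc(Cc2nn3cc(-c4ccc(Cl)cc4Cl)nc3s2)cc1` gives 109000 nM, and the step of an at least 2.2-fold lower number from compound 1 to compound 2 (0.36 log units; beyond the scatter). Compound 3 `Clc1ccc(Cc2nn3cc(-c4ccccc4)nc3s2)cc1` sits at the limit of > 250000 nM. The change an at least 2.2-fold higher number from compound 2 to compound 3 (0.36 log units; beyond the scatter) also concerns that ring, so none of these steps bears on a formyl group, and two of the three values share (the limit of > 250000 nM in this assay, at which 2 of the 3 values shown sit). With nothing to guide direction, the expectation for compound 4 is no step beyond the scatter, giving a number no higher from compound 1 to compound 4 (the limit leaves the size open). Compound 4 is therefore expected at about 250000 nM, within 80000 nM to 600000 nM, most likely again reported only as a limit.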

Compound 4, half-maximal inhibitory concentration: 20000 nM
The estimate for compound 4 lay 13-fold (1.10 log units) above the measured number, outside the stated range (below it).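

Putting formyl in place of hydrogen on the aromatic carbon of the five-membered ring gives an at least 12-fold lower number from compound 1 to compound 4 (1.09 log units; beyond the scatter) in this assay. Among these compounds, the earlier steps all altered the aryl ring, so this is the first sign that this position on the shared core can also shift the read-out. The true size of the step stays unknown because compound 1 has only a limit, not a number: the limit of > 250000 nM in this assay, at which 2 of the 4 values shown sit.

As far as these compounds go, it remains open whether an amine, a carboxylic acid or a hydroxymethyl group at this position would act like formyl. Also open, from the compounds shown here alone, is whether formyl would give a similar step with the 2,4-dichlorophenyl group of compound 2.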